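Hydroxamate-linked quinoline amides: substitution on the aromatic nitrogen

The source may report more compounds than this note shows. Statements on the series, on what has been measured and on what is new or still open speak of the compounds shown alone.

Of the compounds shown here, two have been measured in a functional assay on HCT-116 cells (Homo sapiens) for inhibition, read by MTT assay, with a stated time of 72 h; on this read-out lower numbers stand for stronger inhibition and higher numbers for weaker inhibition. Compound 1 `COc1cc2c(Oc3ccc(NC(=O)c4nn(-c5ccc(C)cc5C)cc(C)c4=O)cc3)ccnc2cc1OCCCCCCC(=O)NO` gives 440 nM in this assay. Compound 2 `COc1cc2c(Oc3ccc(NC(=O)c4nn(-c5ccc(Cl)c(C(F)(F)F)c5)cc(C)c4=O)cc3)ccnc2cc1OCC(=O)NO`, which carries a different chain length and a different aryl group on the aromatic nitrogen, gives 350 nM in this assay. For the measured compounds named here, these two values lie within the usual scatter of each other, so the numbers so far give no read on how either change bears on inhibition.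

Compound 3 `COc1cc2c(Oc3ccc(NC(=O)c4nn(-c5ccccc5)cc(C)c4=O)cc3)ccnc2cc1OCCCCCCC(=O)NO` is not yet measured. It differs from compound 1 in one place: phenyl in place of 2,4-dimethylphenyl on an aromatic nitrogen. Going by the values given here, no measured pair shows this change on its own, so its effect can only be guessed.

For this assay the step from compound 1 to compound 3 is expected to be small, with no clear direction beyond the scatter, because compound 1 gives 440 nM and compound 2 with another aryl group gives 350 nM; the expected step is a 1.3-fold higher number from compound 1 to compound 3 (0.10 log units; within the scatter). Compound 3 is estimated at 550 nM in this assay, with a range from 200 nM to 1500 nM.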

Compound 3, half-maximal inhibitory concentration: 150 nM
The estimate for compound 3 lay 3.7-fold (0.56 log units) above the measured number; the measured number lies below the stated range.
By their numbers in this assay, from the lowest: compound 3; then compounds 2 and 1 (each within the scatter of the next).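

In this assay the aryl group on the aromatic nitrogen proves to be a position that moves the number: phenyl in place of 2,4-dimethylphenyl gives a 2.9-fold lower number from compound 1 to compound 3 (0.47 log units; beyond the scatter), a modest step, but the first in the series that isolates this change and lies beyond the scatter. With the rest of compound 1 held fixed, the methyl groups of the 2,4-dimethylphenyl ring are therefore not needed for inhibition in this cell assay, and the plain phenyl ring gives the lower number of the pair. No measurement available here bears on why the number falls with this change.

The compounds shown do not separate the two methyl groups, so 2-methylphenyl and 4-methylphenyl on the same nitrogen would be needed to tell whether one of them alone accounts for the step, and a 4-fluorophenyl or pyridyl ring would test how far the position tolerates other rings. On these data alone, whether the same step holds on the chain of compound 2 also stays open, since that compound differs from the others in more than one place.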